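From 4-methoxypyridin-2-yl to 4-chloropyridin-2-yl

The source may hold more compounds than are shown below. What is called first, only, known or untested is meant among the compounds shown, and "the series" means these compounds.

In an ADME assay on a cell-free system (plasma, Mus musculus) for metabolic stability, read by LC-MS, tested at 3 uM (on this read-out lower numbers stand for a shorter-lived compound and higher numbers for a longer-lived compound), compound 1 (`C[C@@H](NC(=O)c1nc(-c2cc(C(F)(F)F)ccn2)nc(O)c1O)C1CCCCC1`) gives > 1 h as a limit, not a number. Compound 2 (`COc1ccnc(-c2nc(O)c(O)c(C(=O)N[C@H](C)C3CCCCC3)n2)c1`) gives > 24 h as a limit too, so its standing is known only as a limit. Compound 3 (`C[C@@H](NC(=O)c1nc(-c2cc(Cl)ccn2)nc(O)c1O)C1CCCCC1`) carries chloro in place of methoxy on an aromatic carbon, opposite the ring nitrogen (chloro in place of methoxy on an aromatic carbon). Among the compounds with values here, the one measured step reads a step that the two limits leave unreadable from compound 1 to compound 2 and has methoxy in place of trifluoromethyl. It offers no size to carry over, so no change beyond the scatter is expected in this assay here. The expected step is a number no higher from compound 2 to compound 3 (the limit leaves the size open) as an estimate. Compound 3 is estimated at 24 h with an expected range of 8 h to 48 h and is expected perhaps to stand only as a limit.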

Compound 3, half-life: > 6 h
Compound 3: a limit, no number (the forecaster's own chance of this, stated with the estimate: 65%); the middle value does not contradict the limit.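

Within the data shown here, compound 1, compound 2 and compound 3 all stand only as limits, so no step among them can be read. The compounds shown leave open their actual half-lives and whether trifluoromethyl, methoxy and chloro differ at all.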